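The compounds below may be only part of what the source reports. "The series", "measured", "known", "first", "only" and "open" are said of these compounds alone.

The series is a set of acids carrying a long alkyne-containing chain joined through a benzylic link to a carboxylic acid side chain, tested in an assay on isolated protein for inhibition of Arachidonate 12-lipoxygenase (Sus scrofa); a lower number here means a stronger inhibitor, a higher number a weaker inhibitor. Compound 1 `CCCCCCCCC#CCSCc1cccc(CCC(=O)O)c1` gives in this assay > 10000 nM, which is a limit of the assay rather than a number. Compound 2 `CCCCCCCCCCC#CCOCc1cccc(CCC(=O)O)c1` gives 320 nM in this assay. Compound 3 `CCCCCCCCCCC#CCOCc1ccc(CCCC(=O)O)cc1` gives > 10000 nM in this assay, again a limit and not a number. Compound 3 therefore stands at the weak end of what is shown, at the limit of > 10000 nM in this assay, at which 2 of the 3 values shown sit; only compound 2 returns a measurable number. Among the compounds with values here, no pair of the measured compounds differs in a single place, so no measured step is available to lean on.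

Compound 4 `CCCCCCCCCCC#CCOCc1ccc(C(=O)O)cc1` is not yet measured. Its change from compound 3: carboxy in place of 3-carboxypropyl on an aromatic carbon. Shortening the acid-bearing chain on a compound that itself gives no measurable inhibition has no shown precedent for a gain. The expectation for compound 4 is a step that the limit leaves unreadable from compound 3 to compound 4, that is none beyond the scatter, with a fair chance that only a limit is reported again. The estimate for compound 4 in this assay is 15000 nM, with a range from 3000 nM to 60000 nM.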

Compound 4, half-maximal inhibitory concentration: 60 nM
Compound 4: the middle estimate sits 250-fold (2.40 log units) above what was measured; the measured number lies below the stated range.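

In this assay, within the data shown here, carboxy in place of 3-carboxypropyl on an aromatic carbon para to a large group gives an at least 160-fold lower number from compound 3 to compound 4 (2.22 log units; beyond the scatter), the only single-place step so far. Compound 3 gives > 10000 nM, which is a limit of the assay and not a number, so the size of this step is a bound and not an exact figure: the limit of > 10000 nM in this assay, at which 2 of the 4 values shown sit. The earlier compounds shown here offered no pair differing in one place; this pair shows that the acid-bearing group on this carbon alone can take the read-out from a limit to a measurable number, though that holds for this one pair only.

The compounds shown leave open whether the change is graded or abrupt with the length of the acid-bearing chain, which carboxymethyl and 2-carboxyethyl on the same carbon would address. Also open, from the compounds shown here alone, is whether the acid itself is needed at this place, a question that a tetrazole or a primary amide in place of carboxy on the core of compound 4 would address.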